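A Methyl Group Added to Compound 2

The compounds below may be only part of what the source reports. "The series", "measured", "known", "first", "only" and "open" are said of these compounds alone.

In a functional assay on Raji cells (Homo sapiens) for antiproliferative activity, read by CCK-8 assay, with a stated time of 24 h (on this read-out lower numbers stand for stronger inhibition and higher numbers for weaker inhibition), compound 1 `C=CC(=O)Nc1cccc(Nc2nc(N)nc(Nc3ccc(Oc4ccccc4)cc3)n2)c1` gives 8320 nM, compound 3 `C=CC(=O)Nc1cccc(Nc2nc(N)nc(Nc3ccc(OCCOC)cc3)n2)c1` gives 18300 nM, and compound 2 `C=CC(=O)Nc1cccc(Nc2ncnc(Nc3ccc(C(=O)Nc4ccccn4)cc3)n2)c1` gives 15600 nM. Compound 2 thus holds the second highest of the three numbers, and its value lies within the scatter of both compound 3 and compound 1. Compound 4 `C=CC(=O)Nc1cccc(Nc2ncnc(Nc3ccc(C(=O)Nc4ccc(C)cn4)cc3)n2)c1` differs from compound 2 by methyl in place of hydrogen on an aromatic carbon. For the measured compounds named here, the only measured step, a 2.2-fold higher number from compound 1 to compound 3 (0.34 log units; beyond the scatter), concerns a change on an oxygen and does not bear on a methyl in place of hydrogen on an aromatic carbon. Going by the values given here, no measured step informs this change, so in this assay a step of a 1.0-fold lower number from compound 2 to compound 4 (0.02 log units; within the scatter) is expected, none beyond the scatter. Compound 4 is therefore estimated at 15000 nM, in the range 6000 nM to 38000 nM.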

Compound 4, half-maximal inhibitory concentration: 125000 nM
Estimate against measurement, compound 4: 8.3-fold (0.92 log units) below, outside the stated range (above it).
By their numbers in this assay, from the lowest: compounds 1, 2 and 3 (each within the scatter of the next, the first and the last beyond it); then compound 4.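

In this assay, the change from pyridin-2-yl to 5-methylpyridin-2-yl gives an 8.0-fold higher number from compound 2 to compound 4 (0.90 log units; beyond the scatter). This shows that the aromatic carbon two atoms from the ring nitrogen is sensitive, as a single added carbon with no ring, hydrogen-bond donor or acceptor, or net charge moves the number beyond the scatter. The data offer no explanation for this step. Going by these compounds, what a fluorine, a methoxy group or an amine would do at this same carbon remains open, as does whether methyl on another carbon of that ring would give a step of similar size.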